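Cytotoxicity notes: fluoro for nitro, compound 1 to compound 3

The source may hold more compounds than are shown below. What is called first, only, known or untested is meant among the compounds shown, and "the series" means these compounds.

Measured so far:
compound 1 `O=c1[nH]c2ccccc2cc1-c1nc2cc([N+](=O)[O-])ccc2[nH]1` — > 100000 nM
compound 2 `COc1ccc2[nH]c(=O)c(-c3nc4cc(C)c(C)cc4[nH]3)cc2c1` — > 100000 nM

In an ADME assay on L02 cells (Homo sapiens) for cytotoxicity, read by MTT assay, with a stated time of 48 h (a lower number here means a stronger inhibitor, a higher number a weaker inhibitor), compound 1 gives > 100000 nM, which is a limit of the assay and not a number. In this assay compound 2 gives > 100000 nM, likewise a limit. Among the measured compounds shown here, both readings sit at the limit of > 100000 nM in this assay, at which 2 of the 2 values shown sit, so compound 1 stands on the ceiling of this assay with nothing to separate it from compound 2, and no measured step exists between any two compounds.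

Compound 3 `O=c1[nH]c2ccccc2cc1-c1nc2cc(F)ccc2[nH]1` differs from compound 1 in one place: fluoro in place of nitro on an aromatic carbon. For the measured compounds named here, since both measured compounds only reach the ceiling, there is no measured step that speaks to this change, and the size of any effect in this assay is unknown. With two of two values at the limit, no step beyond the scatter is expected in either direction.

Compound 3 is expected to give about 150000 nM in this assay, with a range from 40000 nM to 600000 nM. The step that the limit leaves unreadable from compound 1 to compound 3 is expected to be none beyond the scatter, and a reading at the limit again is the more likely outcome.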

Compound 3, half-maximal inhibitory concentration: > 100000 nM
Compound 3: only a limit was reported; the forecaster's own chance of this, stated with the estimate: 80%; the middle value lies beyond the limit too.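

In this assay compound 3 gives > 100000 nM, a limit and not a number. Among the compounds shown here, no step from compound 1 to compound 3 can be read, because both compounds sit at the same ceiling: the limit of > 100000 nM in this assay, at which 3 of the 3 values shown sit. The compounds shown leave open whether fluoro in place of nitro has any effect in this assay.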